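Swapping bromo for methoxy on the core of compound 2

The compounds below may be only part of what the source reports. "The series", "measured", "known", "first", "only" and "open" are said of these compounds alone.

Of the compounds shown here, two from this series have been tested in a functional assay on MCF7 cells (Homo sapiens) for cytotoxicity, read by sulforhodamine B assay, with a stated time of 48 h; a higher number here means a weaker inhibitor of growth, a lower number a stronger inhibitor of growth. Compound 1 `COc1ccc2[nH]cc(C(=O)/C(C#N)=C/C=C(\Cl)c3ccc(OC)c(OC)c3)c2c1` gives 44900 nM, and compound 2 `COc1cc(/C(Cl)=C/C=C(\C#N)C(=O)c2c[nH]c3ccc(Br)cc23)cc(OC)c1OC` gives 30800 nM. Compound 2 carries the lower of the two numbers, with compound 1 close by; the gap between them lies within the scatter, so the two show no real difference in growth inhibition. Compound 3 `COc1ccc2[nH]cc(C(=O)/C(C#N)=C/C=C(\Cl)c3cc(OC)c(OC)c(OC)c3)c2c1` has not yet been measured in this assay. It differs from compound 2 by methoxy in place of bromo on an aromatic carbon. Within the data shown here, no measured pair shows this exact exchange, and compound 1, which already carries the methoxy of compound 3, sits at much the same level as compound 2. The change from compound 2 to compound 3 is therefore expected to be a 1.1-fold higher number from compound 2 to compound 3 (0.06 log units; within the scatter), no step beyond the scatter. Compound 3 is estimated at 35000 nM, within a range of 12000 nM to 100000 nM.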

Compound 3, concentration for 50% growth inhibition: 39200 nM
For compound 3 the middle estimate is 1.1-fold (0.05 log units) below the measured one, within the range that was stated.
By their numbers in this assay, from the lowest: compounds 2, 3 and 1 (each within the scatter of the next).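

In this assay, methoxy in place of bromo on an aromatic carbon of the core gives a 1.3-fold higher number from compound 2 to compound 3 (0.10 log units; within the scatter), the first direct measure of this exchange, and at this position the two groups show no real difference in growth inhibition. Compound 3 also allows a second single change to be read, as an added methoxy group gives a 1.1-fold lower number from compound 1 to compound 3 (0.06 log units; within the scatter), and this exchange likewise shows no real difference. Nothing measured here explains why neither change shifts the result.

Going by these compounds, it remains open whether an amine or a carboxylic acid on the same aromatic carbon of the core would move the number beyond the scatter. The same question stands for a longer chain, such as butoxy, in place of the methoxy there.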